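Dimethylamino for Methoxy, Repeated on a Longer Chain

The compounds below may be only part of what the source reports. "The series", "measured", "known", "first", "only" and "open" are said of these compounds alone.

Three compounds have been measured in an assay on isolated protein for inhibition of Amine oxidase [flavin-containing] A (Homo sapiens), read by fluorescence, with a stated time of 30 min; a lower number here means a stronger inhibitor, a higher number a weaker inhibitor:

Compound 1 `CCN(CCCn1sc2cc(OC)c(OC)cc2c1=O)Cc1ccccc1OC` gives 15500 nM.
Compound 2 `CCN(CCCn1sc2cc(OC)c(OC)cc2c1=O)Cc1ccccc1N(C)C` gives 16600 nM.
Compound 3 `CCN(CCCCCCn1sc2cc(OC)c(OC)cc2c1=O)Cc1ccccc1OC` gives 7900 nM.

Compound 1 and compound 2 differ by one change, (dimethylamino in place of methoxy on an aromatic carbon), and that change produced a 1.1-fold higher number from compound 1 to compound 2 (0.03 log units; within the scatter). Compound 3 has the lowest of the three numbers, and how its core differs from the core of compound 1 is not broken down here. Compound 4 `CCN(CCCCCCn1sc2cc(OC)c(OC)cc2c1=O)Cc1ccccc1N(C)C` is not yet measured. It differs from compound 3 by dimethylamino in place of methoxy on an aromatic carbon, the same change as from compound 1 to compound 2, at the same place. The step from compound 3 to compound 4 in this assay is expected to be a 1.1-fold higher number from compound 3 to compound 4 (0.03 log units; within the scatter). That expectation rests on a 1.1-fold higher number from compound 1 to compound 2 (0.03 log units; within the scatter). Compound 4 is therefore estimated at 8500 nM, with a likely range from 4000 nM to 18000 nM.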

Compound 4, half-maximal inhibitory concentration: 3400 nM
Beside the measured number, compound 4's estimate is 2.5-fold (0.40 log units) above it, outside the stated range (below it).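

In this assay, dimethylamino in place of methoxy on the core of compound 3 gave a 2.3-fold lower number from compound 3 to compound 4 (0.37 log units; beyond the scatter). Set beside the earlier step, the two do not separate: the same change on two cores in this assay, a 1.1-fold higher number (0.03 log units; within the scatter) from compound 1 to compound 2 and a 2.3-fold lower number (0.37 log units; beyond the scatter) from compound 3 to compound 4, 2.5-fold (0.40 log units) apart, within the scatter of two such steps. This shows that the change can be carried between these two cores within the usual scatter, but two pairs cannot show that it would carry to other cores in the series, nor can they establish a real difference between the two steps.

The compounds shown leave open how a pyrrolidine or a fluorine would read at the same place. They also leave open whether the same change would give a comparable step on a still longer chain.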